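Taking one chlorine off the benzyl group of compound 1

A few compounds are considered here, and "the series" means these few. Any claim that something is new, unique, unknown or untested is made for them only; others in the source may bear on it.

In a functional assay on GBM1 cells (Homo sapiens) for antiproliferative activity, read by WST assay, with a stated time of 72 h (on this read-out higher numbers stand for weaker inhibition and lower numbers for stronger inhibition), compound 1 `O=C(Nc1cccc(Cl)c1)Nc1cc2ncncc2cc1OCc1ccccc1Cl` gives 2600 nM and compound 2 `O=C(Nc1cc2ncncc2cc1OCc1ccccc1Cl)Nc1cccc2ccccc12` gives 2900 nM on the same read-out. These two values sit level with each other, so compound 1 has no real lead. Compound 3 `O=C(Nc1cccc(Cl)c1)Nc1cc2ncncc2cc1OCc1ccccc1` differs from compound 1 by one small edit hydrogen in place of chloro on an aromatic carbon with hydrogen in place of chloro on an aromatic carbon, so that 2-chlorobenzyl becomes benzyl. Within the data shown here, no measured step touches this group. The nearest guide is a 1.1-fold higher number from compound 1 to compound 2 (0.05 log units; within the scatter) for naphthalen-1-yl in place of 3-chlorophenyl on an amide-type nitrogen, which is a different place in the molecule. From the compounds shown here alone, a step beyond the scatter is therefore not expected, but the direction stays open and the range must stay wide. The estimated step is a 1.2-fold higher number from compound 1 to compound 3 (0.06 log units; within the scatter) with no firm direction behind it. In this assay compound 3 is expected at 3000 nM (estimated range 1200 nM to 7500 nM).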

Compound 3, half-maximal inhibitory concentration: 5700 nM
Compound 3: middle estimate off by 1.9-fold (0.28 log units), on the low side, and the stated range covers the measured number.
By their numbers in this assay, from the lowest: compounds 1, 2 and 3 (each within the scatter of the next, the first and the last beyond it).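

In this assay, hydrogen in place of chloro on the benzyl group gives a 2.2-fold higher number from compound 1 to compound 3 (0.34 log units; beyond the scatter) and so the loss of this one chlorine modestly weakens inhibition. Among these compounds, this is the first step here that lies beyond the usual scatter, which shows that the read-out responds to a change at this place on the 2-chlorobenzyl group, while the change on the amide-type nitrogen gave a 1.1-fold higher number from compound 1 to compound 2 (0.05 log units; within the scatter) and no real separation. No accompanying measurement accounts for the step.

From the compounds shown here alone, whether a fluorine, a methyl or a methoxy group at this same place would match the chlorine, or go beyond it, remains open. Going by these compounds, it is also open whether the chlorine would have a similar effect in compound 2, which carries naphthalen-1-yl instead of 3-chlorophenyl.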